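A few compounds are considered here, and "the series" means these few. Any claim that something is new, unique, unknown or untested is made for them only; others in the source may bear on it.

Compound 1 `COc1ccc(N2C(=O)COc3ccc(-c4cnc(Cl)c(NS(=O)(=O)c5ccc(F)cc5)c4)cc32)cc1` gives 8320 nM
Compound 2 `COc1cccc(N2C(=O)COc3ccc(-c4cnc5ccccc5c4)cc32)c1` gives 11400 nM
Compound 3 `O=C1COc2ccc(-c3cnc4ccccc4c3)cc2N1c1ccc(F)cc1` gives 38800 nM

These values come from a functional assay on HeLa cells (Homo sapiens) for antiproliferative activity, read by MTT assay, with a stated time of 72 h; on this read-out lower numbers stand for stronger inhibition and higher numbers for weaker inhibition. Compound 1 lies within the scatter of compound 2, while compound 3 has a higher number, beyond the scatter. Compound 4 `O=C1COc2ccc(-c3cnc(Cl)c(NS(=O)(=O)c4ccc(F)cc4)c3)cc2N1c1ccccc1` differs from compound 1 by hydrogen in place of methoxy on an aromatic carbon, 4-methoxyphenyl to phenyl (hydrogen in place of methoxy on an aromatic carbon). Among the measured compounds shown here, only one measured step touches the aryl group on the amide-type nitrogen in a ring: a 3.4-fold higher number from compound 2 to compound 3 (0.53 log units; beyond the scatter) (4-fluorophenyl in place of 3-methoxyphenyl). It is modest, swaps a different pair of groups and sits on another core, so it is only a loose guide. A small rise in the number is expected, a 1.6-fold higher number from compound 1 to compound 4 (0.19 log units; within the scatter) (possibly within the scatter). Compound 4 is estimated at 13000 nM (range 5500 nM to 32000 nM).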

Compound 4, half-maximal inhibitory concentration: 10300 nM
The estimate for compound 4 lay 1.3-fold (0.10 log units) above the measured number; the range from low to high includes it.
By their numbers in this assay, from the lowest: compounds 1, 4 and 2 (each within the scatter of the next); then compound 3.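

In this assay, the change from 4-methoxyphenyl to phenyl gives a 1.2-fold higher number from compound 1 to compound 4 (0.09 log units; within the scatter), so on this core the methoxy can be replaced by hydrogen without a change beyond the scatter. Among the compounds shown here, the only earlier step at this aryl group, a 3.4-fold higher number from compound 2 to compound 3 (0.53 log units; beyond the scatter), lay beyond the scatter, but it swapped different groups on another core. No available evidence bears on this result.

On these data alone, whether an amine or a carboxylic acid on this aromatic carbon would move the number remains open. Also open, as far as these compounds go, is whether removing the methoxy would behave alike on the core of compound 2.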